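A few compounds are considered here, and "the series" means these few. Any claim that something is new, unique, unknown or untested is made for them only; others in the source may bear on it.

Three related sulfonamides were tested in a functional assay on MCF7 cells (Homo sapiens) for inhibition, read by MTT assay, with a stated time of 72 h; on this read-out higher numbers stand for weaker inhibition of growth and lower numbers for stronger inhibition of growth. Compound 1 `CC(C)(C)c1ccc(CNCCCNS(=O)(=O)c2cc(C(F)(F)F)cc(C(F)(F)F)c2)cc1` gives 2100 nM. Compound 2 `O=S(=O)(NCCNCc1ccc(-c2ccccc2)cc1)c1cc(C(F)(F)F)cc(C(F)(F)F)c1` gives 1400 nM, and compound 3 `O=S(=O)(NCCCNCc1ccc(-c2ccccc2)cc1)c1cc(C(F)(F)F)cc(C(F)(F)F)c1` gives 1700 nM. These three numbers sit close together, each within the usual scatter of the other two, so none of the three can be called stronger or weaker than another.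

Compound 1 is made from compound 3 by a single change, (tert-butyl in place of phenyl on an aromatic carbon). In this assay that change gave a 1.2-fold higher number from compound 3 to compound 1 (0.09 log units; within the scatter). The cores of compound 2 and compound 3 differ in more than one place, and the difference between the two cores is not broken down here.

Compound 4 `CC(C)(C)c1ccc(CNCCNS(=O)(=O)c2cc(C(F)(F)F)cc(C(F)(F)F)c2)cc1` has not yet been measured. It is made from compound 2 by the same change, (tert-butyl in place of phenyl on an aromatic carbon), at the same kind of place. Because the earlier step was a 1.2-fold higher number from compound 3 to compound 1 (0.09 log units; within the scatter), this change is expected to make a step of similar size, a 1.2-fold higher number from compound 2 to compound 4 (0.08 log units; within the scatter). Compound 4 is therefore estimated at 1700 nM in this assay, most likely between 850 nM and 3400 nM.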

Compound 4, concentration for 50% growth inhibition: 13000 nM
Estimate against measurement, compound 4: 7.6-fold (0.88 log units) below; measured number above the stated range.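

In this assay, putting tert-butyl in place of phenyl on the core of compound 2 gave a 9.3-fold higher number from compound 2 to compound 4 (0.97 log units; beyond the scatter), so on this core the change clearly weakens inhibition of growth. The same swap therefore cannot be carried from one core to the other at a fixed size, since the two pairs give clearly different results: the same change on two cores in this assay, a 1.2-fold higher number (0.09 log units; within the scatter) from compound 3 to compound 1 and a 9.3-fold higher number (0.97 log units; beyond the scatter) from compound 2 to compound 4, 7.5-fold (0.88 log units) apart, beyond the scatter of two such steps

This shows that the effect of the swap depends on the core it is made on, but it does not show which feature of the cores is responsible or how the swap would behave on a third core, and two pairs are too few to set a rule.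

On these data alone, it remains open whether a cyclohexyl ring or a methoxy group on the same aromatic carbon would give a large step or a small one on these two cores. As far as these compounds go, it is also open how the swap would behave on a core with a longer chain linking the sulfonamide to the amine.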